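The compounds below may be only part of what the source reports. "The series", "measured", "known", "first", "only" and "open" are said of these compounds alone.

In a functional assay on A549 cells (Homo sapiens) for cytotoxicity, read by MTT assay, with a stated time of 48 h (a higher number here means a weaker inhibitor, a lower number a stronger inhibitor), compound 1, with the structure `Fc1ccc2nc(-c3cccc(-c4nc5ccc(F)cc5[nH]4)c3)[nH]c2c1`, returns only a limit, > 100000 nM, and no number. Compound 2, `Brc1ccc2nc(-c3cccc(-c4nc5ccc(Br)cc5[nH]4)c3)[nH]c2c1`, gives 21900 nM in this assay. Compound 3, `FC(F)(F)c1ccc2nc(-c3cccc(-c4nc5ccc(C(F)(F)F)cc5[nH]4)c3)[nH]c2c1`, gives 8900 nM in this assay, the lower of the two numbers recorded for this set, and its gap to compound 2 lies beyond the usual scatter of repeated runs. Compound 1 sits at the limit described by the limit of > 100000 nM in this assay, at which 1 of the 3 values shown sits, so no ordering against it can be drawn.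

Compound 4, `O=[N+]([O-])c1cc(-c2nc3ccc(C(F)(F)F)cc3[nH]2)cc(-c2nc3ccc(C(F)(F)F)cc3[nH]2)c1`, differs from compound 3 in one place: nitro in place of hydrogen on an aromatic carbon, a nitro in place of hydrogen on an aromatic carbon of the central ring, meta to two large groups. For the measured compounds named here, no pair of measured compounds shows this kind of change, so its effect here is open. In this assay the expected step is a 1.1-fold lower number from compound 3 to compound 4 (0.05 log units; within the scatter), judged small and not reliably beyond the scatter in either direction. In this assay compound 4 is therefore expected to give about 8000 nM, within a range of 3000 nM to 25000 nM.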

Compound 4, half-maximal inhibitory concentration: 3800 nM
The estimate for compound 4 lay 2.1-fold (0.32 log units) above the measured number; low and high end bracket the measured number.
By their numbers in this assay, from the lowest: compound 4; then compound 3; then compound 2. At a limit, above all of these: compound 1.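

In this assay, this aromatic carbon, meta to two large groups, accepts a nitro group in place of hydrogen without loss of activity: the change gives a 2.3-fold lower number from compound 3 to compound 4 (0.37 log units; beyond the scatter), a modest step. The earlier compounds shown here all carry hydrogen on this carbon, so they gave no reading of any change here, and this pair now shows that the place can be substituted and that the number can move lower. Nothing measured for these compounds accounts for the step.

On these data alone, whether the step is particular to nitro stays open, as an amine, a nitrile or a carboxylic acid on the same aromatic carbon would be needed to tell. As far as these compounds go, it is equally open whether the same change would shift the number for compound 2, which carries bromine in place of trifluoromethyl.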